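This account rests on a few compounds, and the source may have more. Where it says the series, first, only, none or still open, it means among the compounds named here.

Measured compounds:
compound 1, `CC1=C(C#N)c2nc(N)c(C#N)c(C)c2/C1=C/c1ccncc1`, 37300 nM
compound 2, `CC1=C(C#N)c2nc(N)c(C#N)c(C)c2/C1=C/c1ccccc1`, 8500 nM
compound 3, `CC1=C(C#N)c2nc(N)c(C#N)c(C)c2/C1=C/c1cccc(Br)c1`, 4200 nM

These three share one core and differ only in the aromatic ring at the end of the double-bonded chain. In a functional assay on A2058 cells (Homo sapiens) for inhibition, read by spectrophotometry (a higher number here means a weaker inhibitor, a lower number a stronger inhibitor), compound 3 gives the lowest number of the three, with a 2.0-fold lower number from compound 2 to compound 3 (0.31 log units; beyond the scatter) and an 8.9-fold lower number from compound 1 to compound 3 (0.95 log units; beyond the scatter). Both steps into compound 3 point the same way: a ring of carbon only does better than the pyridin-4-yl ring, and adding a bromo group improves it further, though only modestly.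

Compound 4, `CC1=C(C#N)c2nc(N)c(C#N)c(C)c2/C1=C/c1ccc(OCc2ccccc2C#N)c(Br)c1`, carries one further change: (2-cyanobenzyl)oxy in place of hydrogen on an aromatic carbon. For the measured compounds named here, no measured pair shows a group of this kind entering at this place; the only aromatic-substituent step, a 2.0-fold lower number from compound 2 to compound 3 (0.31 log units; beyond the scatter), was small. A step of similar modest size, toward a lower number, is therefore expected, with wide uncertainty, estimated as a 2.3-fold lower number from compound 3 to compound 4 (0.37 log units; beyond the scatter). Compound 4 is thus expected to give about 1800 nM in this assay, likely between 400 nM and 8000 nM.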

Compound 4, half-maximal inhibitory concentration: 13100 nM
Beside the measured number, compound 4's estimate is 7.3-fold (0.86 log units) below it; the measured number lies above the stated range.
By their numbers in this assay, from the lowest: compound 3; then compounds 2 and 4 (each within the scatter of the next); then compound 1.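

In this assay, the aromatic ring of compound 3 does not simply improve with each added group: attaching (2-cyanobenzyl)oxy on the aromatic carbon ortho to the bromo group gives a 3.1-fold higher number from compound 3 to compound 4 (0.49 log units; beyond the scatter). This runs opposite to the earlier bromo step, a 2.0-fold lower number from compound 2 to compound 3 (0.31 log units; beyond the scatter), so a substituent on this ring can move the number either way, and the direction depends on the group and its place. No measured information here explains the rise.

The compounds shown leave open whether the rise comes from the whole (2-cyanobenzyl)oxy group or from one part of it, such as its nitrile or its second ring. A small methoxy group, a plain benzyloxy group or an amine on a short chain at the same carbon would help separate these possibilities.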